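From Cyclopropyl to Difluorophenyl: What to Expect

This account rests on a few compounds, and the source may have more. Where it says the series, first, only, none or still open, it means among the compounds named here.

Of the compounds shown here, three sharing one core have been tested in a functional assay on SW-620 cells (Homo sapiens) for antiproliferative activity, read by MTT assay, with a stated time of 72 h; a lower number here means a stronger inhibitor, a higher number a weaker inhibitor. Compound 1 `COc1ccccc1-c1cn(C[C@H](O)[C@H]2OC(=O)C(OCc3ccccc3)=C2OCc2ccccc2)nn1` gives only a limit there, > 100000 nM. Compound 2 `CC(C)(C)c1cn(C[C@H](O)[C@H]2OC(=O)C(OCc3ccccc3)=C2OCc2ccccc2)nn1` gives 35800 nM. Compound 3 `O=C1O[C@H]([C@@H](O)Cn2cc(C3CC3)nn2)C(OCc2ccccc2)=C1OCc1ccccc1` gives 54200 nM, the higher of the two numbers, though the step of a 1.5-fold higher number from compound 2 to compound 3 (0.18 log units; within the scatter) lies within the scatter. The step of an at least 1.8-fold lower number from compound 1 to compound 3 (0.26 log units; that floor lies within the scatter) shows that trading an aromatic ring for cyclopropyl did not clearly change the number. Compound 4 `O=C1O[C@H]([C@@H](O)Cn2cc(-c3cc(F)cc(F)c3)nn2)C(OCc2ccccc2)=C1OCc1ccccc1` is compound 3 with 3,5-difluorophenyl in place of cyclopropyl on an aromatic carbon. Compound 1 also carries an aromatic ring on that aromatic carbon and reaches only the limit. Within the data shown here, a move toward a weaker result is possible, yet the one relevant step, an at least 1.8-fold lower number from compound 1 to compound 3 (0.26 log units; that floor lies within the scatter), is small. Compound 4 is therefore expected to give 80000 nM, between 30000 nM and 200000 nM, a change of a 1.5-fold higher number from compound 3 to compound 4 (0.17 log units; within the scatter).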

Compound 4, half-maximal inhibitory concentration: > 100000 nM
Compound 4 gave a limit, no number (the forecaster's own chance of this, stated with the estimate: 40%); at least 1.2-fold (0.09 log units) between middle value and limit.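

In this assay, 3,5-difluorophenyl on this aromatic carbon clearly weakens the result against tert-butyl, an at least 2.7-fold higher number from compound 2 to compound 4 (0.44 log units; beyond the scatter), while against cyclopropyl, an at least 1.8-fold higher number from compound 3 to compound 4 (0.26 log units; that floor lies within the scatter), the floor of the step stays within the scatter. The step between compound 1 and compound 4 cannot be read, as both values are limits. A six-membered aromatic ring on this carbon has now ended at the same point twice: the limit of > 100000 nM in this assay, at which 2 of the 4 values shown sit.

Going by these compounds, whether an amine, a carboxylic acid or a longer chain on this carbon would give a lower number than tert-butyl stays open. So does how far the true values of compound 1 and compound 4 lie past that limit.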